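Dropping one trifluoromethyl from a bis-substituted urea aryl

The source may hold more compounds than are shown below. What is called first, only, known or untested is meant among the compounds shown, and "the series" means these compounds.

Three compounds of one series share a core in which a pyrazole bearing a pyridyl and a chloro-substituted phenol or anisole carries an aryl urea. Compound 1 `O=C(Nc1cccc(-n2cc(-c3ccncc3)c(-c3cc(O)cc(Cl)c3)n2)c1)Nc1ccc(Cl)c(C(F)(F)F)c1` gives 99% in a functional assay on UACC-62 cells (Homo sapiens) for inhibition, read by sulforhodamine B assay, with a stated time of 48 h, tested at 1 uM; on this read-out higher numbers stand for a weaker effect at the one concentration tested and lower numbers for a stronger effect. Compound 2 `COc1cc(Cl)cc(-c2nn(-c3cccc(NC(=O)Nc4ccc(Cl)c(C(F)(F)F)c4)c3)cc2-c2ccncc2)c1` gives 82% in this assay, and the change from compound 1 to compound 2 is a number 17 percentage points lower from compound 1 to compound 2 (beyond the scatter). Compound 3 `COc1cc(Cl)cc(-c2nn(-c3cccc(NC(=O)Nc4cc(C(F)(F)F)cc(C(F)(F)F)c4)c3)cc2-c2ccncc2)c1` gives 18% in this assay, the lowest of the three numbers and therefore the strongest effect at the concentration tested, separated from compound 2 and from compound 1 by gaps well beyond the scatter.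

Compound 4 `COc1cc(Cl)cc(-c2nn(-c3cccc(NC(=O)Nc4cccc(C(F)(F)F)c4)c3)cc2-c2ccncc2)c1` is the next step. Compared with compound 3 the difference is hydrogen in place of trifluoromethyl on an aromatic carbon.

Going by the values given here, no measured step alters the urea aryl in this way, so the one recorded step, from compound 1 to compound 2 at the oxygen of the other aryl, does not bear directly on it. What the numbers do show is that compound 3, with two trifluoromethyl groups, sits far below compound 2, whose aryl carries a different pair of substituents. The author expects the removal of one trifluoromethyl to move compound 4 upward, an estimated step of a number 32 percentage points higher from compound 3 to compound 4 (beyond the scatter) in this assay. Compound 4 is therefore estimated at 50% in this assay, within a range from 20% to 90%.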

Compound 4, a percentage reported as activity, at one concentration (the size of the read-out at that concentration, not a potency): 70%
For compound 4 the middle estimate is 20 percentage points below the measured one, within the range that was stated.
By their numbers in this assay, from the lowest: compound 3; then compound 4; then compound 2; then compound 1.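

In this assay, the trifluoromethyl meta to a trifluoromethyl group proves to carry much of the effect of compound 3: replacing it with hydrogen gives a number 52 percentage points higher from compound 3 to compound 4 (beyond the scatter), a large step. Going by these compounds alone, no earlier pair changed this aryl at one place alone. Removing a substituent from the urea aryl does not act in one direction, however, since hydrogen in place of chloro gives a number 12 percentage points lower from compound 2 to compound 4 (beyond the scatter), a modest step towards a stronger effect, whereas the loss of trifluoromethyl moves the number the other way and much further. Nothing at hand accounts for either step or for the contrast between them.

The compounds shown leave open what a nitrile, a methyl or an amine would do in place of the departed trifluoromethyl, and how the fully unsubstituted urea aryl would read. They also leave open whether the step from hydroxyl to methoxy on the other aryl, seen so far with only the chloro and trifluoromethyl pair, would have the same size with two trifluoromethyl groups on the urea aryl.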